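The source may hold more compounds than are shown below. What is called first, only, known or untested is meant among the compounds shown, and "the series" means these compounds.

Compound 1 `C=CCOc1c(C)c(C)c2c(c1C)CCC(C)(COc1ccc(/C=C3\SC(=O)NC3=O)cc1)O2`: 45%; compound 2 `Cc1c(C)c2c(c(C)c1OC(=O)CCC(=O)O)CCC(C)(COc1ccc(/C=C3\SC(=O)NC3=O)cc1)O2`: 115%; compound 3 `CCOc1cc(/C=C2\SC(=O)NC2=O)ccc1OCC1(C)CCc2c(C)c(OCC=C(C)C)c(C)c(C)c2O1`: 107%.

In a functional assay on MCF7 cells (Homo sapiens), tested at 2.5 uM (a higher number here means a weaker effect of the compound at the concentration tested, a lower number a stronger effect), compound 3 gives 107%, the second highest of the three numbers; its nearest neighbour is compound 2 with 115%, within the scatter, while compound 1 with 45% lies far below it. Compound 4 `CC(C)=CCOc1c(C)c(C)c2c(c1C)CCC(C)(COc1ccc(/C=C3\SC(=O)NC3=O)cc1)O2` differs from compound 3 by hydrogen in place of ethoxy on an aromatic carbon. Within the data shown here, the only measured step, a number 70 percentage points higher from compound 1 to compound 2 (beyond the scatter), concerns a different oxygen and does not bear on this change, so no step in this assay can be inferred from the data. Compound 4 is therefore expected to lie between the values of compound 1 and compound 3, an estimated 80% (range 45% to 115%), corresponding to an expected step of a number 27 percentage points lower from compound 3 to compound 4 (beyond the scatter).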

Compound 4, a percentage reported as activity, at one concentration (the size of the read-out at that concentration, not a potency): 76%
Compound 4: the middle estimate sits 4 percentage points above what was measured; low and high end bracket the measured number.
By their numbers in this assay, from the lowest: compound 1; then compound 4; then compounds 3 and 2 (each within the scatter of the next).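

In this assay, hydrogen in place of ethoxy on this aromatic carbon gives a number 31 percentage points lower from compound 3 to compound 4 (beyond the scatter) and thus a stronger effect, the first sign that this position alone can shift the read-out beyond the scatter. With that hydrogen present, the group on the ring oxygen still counts: 3-methylbut-2-en-1-yl in place of (2-carboxyethyl)carbonyl gives a number 39 percentage points lower from compound 2 to compound 4 (beyond the scatter) as a stronger effect, while 2-methylprop-1-en-1-yl in place of vinyl gives a number 31 percentage points higher from compound 1 to compound 4 (beyond the scatter) as a weaker one. Nothing measured here explains these steps. From the compounds shown here alone, whether a methoxy or an amine on that aromatic carbon would act like ethoxy or like hydrogen stays open. So does whether ethoxy would shift the read-out equally with allyl on the ring oxygen.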